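Swapping the Aryl Group on the Amine of Compound 1

This account rests on a few compounds, and the source may have more. Where it says the series, first, only, none or still open, it means among the compounds named here.

For the measured compounds named here, compound 1, `Cc1ccc(NC2=CC(=O)c3nc4n(c3C2=O)[C@H]2OC[C@@H](O)[C@H]2OC4)cc1C`, is one of three compounds measured in a functional assay on MGC-803 cells (Homo sapiens) for inhibition, read by sulforhodamine B assay (on this read-out lower numbers stand for stronger inhibition and higher numbers for weaker inhibition), where compound 1 gives 860 nM. Compound 2, `CCOc1ccc(NC2=CC(=O)c3c(nc4n3[C@H]3OC[C@@H](O)[C@H]3OC4)C2=O)cc1`, gives 2090 nM, and compound 3, `COc1ccccc1NC1=CC(=O)c2c(nc3n2[C@H]2OC[C@@H](O)[C@H]2OC3)C1=O`, gives 1670 nM. Compound 1 shows the lowest number of the three; its nearest neighbour is compound 3, within the scatter, while compound 2 lies beyond it. Going by the values given here, the only measured step among aryl groups on the amine nitrogen, a 1.3-fold lower number from compound 2 to compound 3 (0.10 log units; within the scatter), stays within the scatter.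

Compound 4, `O=C1C=C(Nc2ccc(C(F)(F)F)cc2)C(=O)c2c1nc1n2[C@H]2OC[C@@H](O)[C@H]2OC1`, arises from compound 1 by one change: 4-(trifluoromethyl)phenyl in place of 3,4-dimethylphenyl on an amine nitrogen. Among the compounds with values here, no measured step swaps a dimethyl-substituted phenyl for a trifluoromethyl-substituted one, so the single aryl step available, which was small, is the only guide. A step of a 1.4-fold higher number from compound 1 to compound 4 (0.14 log units; within the scatter) is therefore expected, within the scatter. Compound 4 is estimated to give 1200 nM in this assay, with a range from 500 nM to 3000 nM.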

Compound 4, half-maximal inhibitory concentration: 2820 nM
Compound 4: the middle estimate sits 2.4-fold (0.37 log units) below what was measured; the range from low to high includes it.
By their numbers in this assay, from the lowest: compounds 1, 3, 2 and 4 (each within the scatter of the next, the first and the last beyond it).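

The change from 3,4-dimethylphenyl to 4-(trifluoromethyl)phenyl on the amine nitrogen gives a 3.3-fold higher number from compound 1 to compound 4 (0.52 log units; beyond the scatter) in this assay. For the compounds shown here, this shows that the number in this assay can respond to the aryl group at this position, which the one earlier step, a 1.3-fold lower number from compound 2 to compound 3 (0.10 log units; within the scatter), could not show. Nothing measured here explains the shift.

Two things changed at once, since the two methyl groups left and a trifluoromethyl group entered, so the compounds shown cannot separate the effect of losing the methyl groups from that of adding the trifluoromethyl group. Also open, on these data alone, is how this position would respond to a phenyl ring carrying a single methyl group or a chlorine atom, or to a non-aromatic chain ending in an amine.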